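Swapping furan-2-yl for 4-(dimethylamino)phenyl on the shared core

A few compounds are considered here, and "the series" means these few. Any claim that something is new, unique, unknown or untested is made for them only; others in the source may bear on it.

Measured in an ADME assay on CCRF-CEM cells (Homo sapiens) for cytotoxicity, read by MTT assay, with a stated time of 72 h (on this read-out lower numbers stand for higher toxicity in this test and higher numbers for lower toxicity in this test), so far:
Compound 1 `CC(=O)c1c(O)c(C(C)=O)c(O)c(C(c2c(O)c(C(C)=O)c(O)c(C(C)=O)c2O)C2CCCCC2)c1O` gives 58900 nM
Compound 2 `CC(=O)c1c(O)c(C(C)=O)c(O)c(C(c2ccc(O)cc2)c2c(O)c(C(C)=O)c(O)c(C(C)=O)c2O)c1O` gives "not determined" (no result reported)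
Compound 3 `CC(=O)c1c(O)c(C(C)=O)c(O)c(C(c2ccco2)c2c(O)c(C(C)=O)c(O)c(C(C)=O)c2O)c1O` gives 61200 nM

Compound 3, at 61200 nM, cannot be told apart from compound 1, at 58900 nM, and compound 2 adds no number to compare. The next compound, compound 4 `CC(=O)c1c(O)c(C(C)=O)c(O)c(C(c2ccc(N(C)C)cc2)c2c(O)c(C(C)=O)c(O)c(C(C)=O)c2O)c1O`, has not yet been measured in this assay. It carries 4-(dimethylamino)phenyl in place of furan-2-yl on a saturated chain carbon bound to two aromatic carbons. Within the data shown here, only one measured step bears on this place, furan-2-yl in place of cyclohexyl, and it is a 1.0-fold higher number from compound 1 to compound 3 (0.02 log units; within the scatter). That single step is thin evidence, but it gives no reason to expect a large change, and a shift to either side remains possible. The estimate is therefore a 1.2-fold lower number from compound 3 to compound 4 (0.09 log units; within the scatter), with no expected change beyond the scatter. For compound 4 the expected value is 50000 nM, with an estimated range of 20000 nM to 110000 nM.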

Compound 4, half-maximal cytotoxic concentration: 22100 nM
Beside the measured number, compound 4's estimate is 2.3-fold (0.35 log units) above it, and the stated range covers the measured number.
By their numbers in this assay, from the lowest: compound 4; then compounds 1 and 3 (each within the scatter of the next).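

At this saturated chain carbon bound to two aromatic carbons, the choice of group can shift the number in this assay: 4-(dimethylamino)phenyl in place of furan-2-yl gives a 2.8-fold lower number from compound 3 to compound 4 (0.44 log units; beyond the scatter), and in place of cyclohexyl it gives a 2.7-fold lower number from compound 1 to compound 4 (0.43 log units; beyond the scatter). Among these compounds, the earlier swap of cyclohexyl for furan-2-yl stayed within the scatter, so compound 4 is the first compound here to stand apart, with the lower number indicating higher toxicity in this test. Nothing available here explains this shift.

The compounds shown do not separate the contribution of the dimethylamino group from that of the phenyl ring carrying it, and compound 2 has no reported result. On these data alone, whether an unsubstituted phenyl group or a 4-aminophenyl group at this place would match compound 4 remains open.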